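The source may report more compounds than this note shows. Statements on the series, on what has been measured and on what is new or still open speak of the compounds shown alone.

Working notes on the series. Among the measured compounds shown here, compound 3 `CN(C)CCCCOc1ccc2oc(-c3ccccc3)cc(=O)c2c1` gives 720 nM in an assay on isolated protein (Cavia porcellus) with Sigma non-opioid intracellular receptor 1 (Homo sapiens) as the target, read by radioligand binding (a higher number here means a weaker inhibitor, a lower number a stronger inhibitor), the highest of the three numbers so far. Compound 1 `O=c1cc(-c2ccccc2)oc2cccc(OCCCN3CCC(O)CC3)c12` gives 125 nM in this assay, and compound 2 `O=c1cc(-c2ccccc2)oc2cccc(OCCCCCCCN3CCC(O)CC3)c12` gives 36 nM; both differences from compound 3 lie beyond the scatter. Compound 4 `CN(C)CCCCCCCCCOc1ccc2oc(-c3ccccc3)cc(=O)c2c1` is not yet measured. It differs from compound 3 in one place: 5-(dimethylamino)pentyl in place of dimethylamino on a saturated chain carbon, four bonds along the chain from an oxygen on an aromatic ring. For the measured compounds named here, no directly comparable step is measured. Compound 2 and compound 1 differ, among other things, in chain length, with the longer chain of compound 2 at the lower number, so a lowering is expected for compound 4 as well, of moderate size. The step from compound 3 to compound 4 is expected to be a 4.0-fold lower number from compound 3 to compound 4 (0.60 log units; beyond the scatter). Compound 4 is estimated at 180 nM, with a range from 60 nM to 500 nM.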

Compound 4, half-maximal inhibitory concentration: 334 nM
Beside the measured number, compound 4's estimate is 1.9-fold (0.27 log units) below it; low and high end bracket the measured number.
By their numbers in this assay, from the lowest: compound 2; then compound 1; then compound 4; then compound 3.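

In this assay, among the compounds shown here, 5-(dimethylamino)pentyl in place of dimethylamino gives a 2.2-fold lower number from compound 3 to compound 4 (0.33 log units; beyond the scatter) and is the only step read. At this position, with the shared core and the terminal dimethylamino group unchanged, a longer chain therefore carries a modest lowering of the number. No supporting data bear on the origin of this step. From the compounds shown here alone, whether a still longer chain lowers the number further remains open. So does the effect of replacing the terminal dimethylamino group with a primary amine or a carboxylic acid.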